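A few compounds are considered here, and "the series" means these few. Any claim that something is new, unique, unknown or untested is made for them only; others in the source may bear on it.

Measured compounds:
- compound 1 `CS(=O)(=O)c1ccc(C(=O)Nc2ccc(Cl)c(-c3nnc4c(Cl)cccn34)c2)c(Cl)c1` gives > 100000 nM in a functional assay on MDA-MB-468 cells (Homo sapiens) for antiproliferative activity, read by MTT assay, with a stated time of 72 h; a higher number here means a weaker inhibitor, a lower number a stronger inhibitor; this is a limit of the assay, not a number.
- compound 2 `O=C(Nc1ccc(Cl)c(-c2nnc3c(Cl)cccn23)c1)c1ccccc1Cl` gives > 100000 nM in this assay; again a limit.
- compound 3 `O=C(Nc1ccc(Cl)c(-c2nnc3c(Cl)cccn23)c1)c1ccc(C(F)(F)F)cc1Cl` gives > 100000 nM in this assay; again a limit.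

All three measured compounds therefore sit at the same ceiling, (the limit of > 100000 nM in this assay, at which 3 of the 3 values shown sit), and compound 2 stands exactly there, with no number of its own to compare. The steps between them cannot be read: a step that the two limits leave unreadable from compound 1 to compound 2, a step that the two limits leave unreadable from compound 1 to compound 3 and a step that the two limits leave unreadable from compound 2 to compound 3 all end at a limit on both sides, so nothing can be said about whether a hydrogen, a trifluoromethyl or a methylsulfonyl on the aromatic carbon changes anything.

Compound 4 `CS(=O)(=O)c1cccc(C(=O)Nc2ccc(Cl)c(-c3nnc4c(Cl)cccn34)c2)c1` is the next compound, and it differs from compound 2 as follows: 3-(methylsulfonyl)phenyl in place of 2-chlorophenyl on a carbonyl carbon. Going by the values given here, no measured step bears on this exchange, since every step available is unreadable. Among the compounds with values here, the only guide is that three related amides, with quite different groups on that phenyl ring, all failed to reach a measurable half-maximal inhibitory concentration.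

For compound 4 the expected outcome in this assay is again a limit rather than a number, with an estimated value of 150000 nM (range 40000 nM to 500000 nM). The step expected from compound 2 to compound 4 is a step that the limit leaves unreadable from compound 2 to compound 4, which means essentially no change.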

Compound 4, half-maximal inhibitory concentration: > 100000 nM
Compound 4: no number, only a limit; the forecaster's own chance of this, stated with the estimate: 80%; the middle value does not contradict the limit.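

In this assay compound 4 gives > 100000 nM, which is a limit of the assay and not a number. Compound 2 also stands at a limit, so the step between compound 2 and compound 4 cannot be read: the limit of > 100000 nM in this assay, at which 4 of the 4 values shown sit.

The compounds shown leave open whether any group on the phenyl ring of these amides can give a measurable half-maximal inhibitory concentration.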